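Moving the Hydroxy Group on the Aryl Ring

The source may hold more compounds than are shown below. What is called first, only, known or untested is meant among the compounds shown, and "the series" means these compounds.

Compound 3 `Cc1ccc2nc(C)n(NC(=O)/C(C#N)=C/c3cccc(O)c3)c(=O)c2c1` carries the highest of the three numbers measured in a functional assay on HeLa cells (Homo sapiens) for cytotoxicity, read by MTT assay, with a stated time of 3 days (on this read-out lower numbers stand for stronger inhibition and higher numbers for weaker inhibition), where compound 3 gives 14000 nM. Its nearest neighbour is compound 1 `Cc1ccc2nc(C)n(NC(=O)/C(C#N)=C/c3ccccc3)c(=O)c2c1`, which in this assay gives 13000 nM, and the furthest is compound 2 `Cc1ccc2nc(C)n(NC(=O)/C(C#N)=C/c3ccc(Cl)cc3)c(=O)c2c1`, which gives 12000 nM. Both gaps, a 1.1-fold higher number from compound 1 to compound 3 (0.03 log units; within the scatter) and a 1.2-fold higher number from compound 2 to compound 3 (0.07 log units; within the scatter), lie within the scatter, so nothing separates the three compounds.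

Compound 4 `Cc1ccc2nc(C)n(NC(=O)/C(C#N)=C/c3ccc(O)cc3)c(=O)c2c1` differs from compound 3 in one place: 4-hydroxyphenyl in place of 3-hydroxyphenyl on a double-bonded chain carbon bound to a double-bonded chain carbon. The measured steps that bear on this change are all small. Introducing a hydroxy group onto the ring, a 1.1-fold higher number from compound 1 to compound 3 (0.03 log units; within the scatter), changed little; the chloro substitution, a 1.1-fold lower number from compound 1 to compound 2 (0.03 log units; within the scatter), changed little; and the exchange of one substituted ring for another, a 1.2-fold higher number from compound 2 to compound 3 (0.07 log units; within the scatter), changed little as well. Every alteration of this ring seen so far has stayed within the scatter, and nothing in these three compounds suggests that relocating the hydroxy group will behave differently.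

Compound 4 is therefore expected to show a step of a 1.1-fold lower number from compound 3 to compound 4 (0.03 log units; within the scatter), that is, none beyond the scatter. The estimate for compound 4 in this assay is 13000 nM, with a range from 7000 nM to 25000 nM.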

Compound 4, half-maximal inhibitory concentration: 13000 nM
Compound 4: the middle estimate sits on the measured number at the digits printed; the range from low to high includes it.
By their numbers in this assay, from the lowest: compounds 2, 1, 4 and 3 (each within the scatter of the next).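

Moving the hydroxy group, with 4-hydroxyphenyl in place of 3-hydroxyphenyl on a double-bonded chain carbon bound to a double-bonded chain carbon, gives a 1.1-fold lower number from compound 3 to compound 4 (0.03 log units; within the scatter) in this assay, so the first isomer pair in the series shows no readable dependence on where the hydroxy group sits on this ring. The two further steps extend this picture: hydroxy in place of chloro on an aromatic carbon gives a 1.1-fold higher number from compound 2 to compound 4 (0.03 log units; within the scatter), and hydroxy in place of hydrogen on an aromatic carbon gives no change at the digits printed from compound 1 to compound 4 (within the scatter), so the 4-hydroxyphenyl compound cannot be told apart from the unsubstituted or the 4-chlorophenyl compound. Nothing available here offers an explanation for why these ring changes leave the number within the scatter.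

All the changes shown lie on the aryl ring and involve only hydroxy or chloro, so it remains open whether an amine or a carboxylic acid on that ring would give a step beyond the scatter. The compounds also leave open what happens away from the ring, for example with a carboxylic acid in place of the nitrile or a longer chain in place of a methyl group on the shared core.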